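A few compounds are considered here, and "the series" means these few. Any claim that something is new, unique, unknown or untested is made for them only; others in the source may bear on it.

Measured compounds:
- compound 1, `N#Cc1cnc(NCc2cncnc2-c2ccccc2)cc1N[C@H]1CC[C@@H](O)CC1`; in an assay on isolated protein for inhibition of protein kinase C theta type (Homo sapiens), read by TR-FRET, with a stated time of 2 h (on this read-out lower numbers stand for stronger inhibition and higher numbers for weaker inhibition), compound 1 gives 90 nM
- compound 2, `CC(C)(C)Oc1ncncc1CNc1cc(N[C@H]2CC[C@@H](O)CC2)c(C#N)cn1`; in this assay compound 2 gives 200 nM
- compound 3, `N#Cc1cnc(NCc2cncnc2OCC(F)F)cc1N[C@H]1CC[C@@H](O)CC1`, not yet measured

Among the compounds with values here, compound 2 stands at the higher of the two numbers so far, the only measured step being a 2.2-fold higher number from compound 1 to compound 2 (0.35 log units; beyond the scatter). Compound 3 keeps the whole of compound 2 except for one change: 2,2-difluoroethyl in place of tert-butyl on an oxygen on an aromatic ring. Within the data shown here, no measured step touches the group on this oxygen; the single known step swaps phenyl for tert-butoxy, a different kind of change, so it gives no direct guide. With nothing to point either way, only a small step in this assay is expected, perhaps towards a slightly higher number. Compound 3 is therefore expected to give about 250 nM, with a range from 90 nM to 700 nM. That estimate means a 1.3-fold higher number from compound 2 to compound 3 (0.10 log units; within the scatter), which is expected to fall within the ordinary scatter.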

Compound 3, half-maximal inhibitory concentration: 90 nM
Compound 3: middle estimate off by 2.8-fold (0.44 log units), on the high side; low and high end bracket the measured number.
By their numbers in this assay, from the lowest: compounds 1 and 3 (each within the scatter of the next); then compound 2.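

In this assay, changing the group on this oxygen on an aromatic ring from tert-butyl to 2,2-difluoroethyl gives a 2.2-fold lower number from compound 2 to compound 3 (0.35 log units; beyond the scatter), even though both groups count 4 heavy atoms. Within the data shown here, the earlier compounds showed only a swap of phenyl for tert-butoxy, so this is the first sign that the group on the oxygen itself can shift the number beyond the scatter. Replacing phenyl with 2,2-difluoroethoxy on the aromatic carbon gives no change at the digits printed from compound 1 to compound 3 (within the scatter), so in this pair a group without a ring matches phenyl.

The compounds shown cannot tell whether the step belongs to the fluorine atoms or to the carbon skeleton, and a plain ethyl group on the same oxygen would separate the two. No measurement offered here accounts for any of these numbers, so the reason for the step stays open.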